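Swapping the amide aryl group on a shared core

This account rests on a few compounds, and the source may have more. Where it says the series, first, only, none or still open, it means among the compounds named here.

Three amides on a shared core have been tested. Compound 1 `Cc1nc(C(=O)Nc2ccc(Cl)c(-c3nnc4c(Cl)cccn34)c2)cs1` gives in a functional assay on MCF7 cells (Homo sapiens) for antiproliferative activity, read by MTT assay, with a stated time of 72 h (on this read-out higher numbers stand for weaker inhibition and lower numbers for stronger inhibition), a value of > 100000 nM, which is a limit of the assay rather than a number. Compound 2 `O=C(Nc1ccc(Cl)c(-c2nnc3c(Cl)cccn23)c1)c1ccc(Cl)cc1` gives 58400 nM in this assay. Compound 3 `O=C(Nc1ccc(Cl)c(-c2nnc3c(Cl)cccn23)c1)c1c(F)cccc1Cl` also reaches only a limit in this assay, at > 100000 nM. Compound 3 thus stands at the limit of > 100000 nM in this assay, at which 2 of the 3 values shown sit. Compound 4 `O=C(Nc1ccc(Cl)c(-c2nnc3c(Cl)cccn23)c1)c1cccnc1Cl` carries 2-chloropyridin-3-yl in place of 2-chloro-6-fluorophenyl on a carbonyl carbon. Within the data shown here, the steps that bear on this change are an at least 1.7-fold higher number from compound 2 to compound 3 (0.23 log units; that floor lies within the scatter) and a step that the two limits leave unreadable from compound 1 to compound 3; neither passes the scatter, and no measured step shows a 2-chloropyridin-3-yl group entering. Compound 4 is therefore expected to give 100000 nM (range 40000 nM to 200000 nM) in this assay, most likely again a limit. The expected step of a number no higher from compound 3 to compound 4 (the limit leaves the size open) is estimated to stay within the scatter.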

Compound 4, half-maximal inhibitory concentration: > 100000 nM
Compound 4: only a limit was reported; the forecaster's own chance of this, stated with the estimate: 60%; the middle value sits exactly at the limit.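

Putting 2-chloropyridin-3-yl in place of 2-chloro-6-fluorophenyl on the carbonyl carbon brings a ring nitrogen into this position, yet this assay still returns only a limit for compound 4, and steps between two limits cannot be read. Among these compounds, the one readable step is an at least 1.7-fold higher number from compound 2 to compound 4 (0.23 log units; that floor lies within the scatter). Among the groups shown at this position, only 4-chlorophenyl gives a number, and the 2-chloropyridin-3-yl group joins the others at the limit: the limit of > 100000 nM in this assay, at which 3 of the 4 values shown sit.

The compounds shown leave open whether any other group here, such as a 4-aminophenyl or a piperidine, would give a number well clear of that limit. They also leave open how far compound 1, compound 3 and compound 4 truly lie from one another.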